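A Methyl Group Added Where Little Inhibition Was Seen

The source may hold more compounds than are shown below. What is called first, only, known or untested is meant among the compounds shown, and "the series" means these compounds.

Compound 1 `CNC(=O)/C=C1/COc2cc(OS(=O)(=O)c3cccc(Cl)c3)ccc21` was tested in an assay (strain Sprague-Dawley) for inhibition of Amine oxidase [flavin-containing] B (Rattus norvegicus), read by spectrophotometry, with a stated time of 5 min, tested at 10 uM (a lower number here means less inhibition, a higher number more inhibition at the concentration tested (going by the name of the read-out)), where compound 1 gives 0%. Compound 2 `CNC(=O)/C=C1/COc2cc(OS(=O)(=O)c3ccc(Cl)cc3)ccc21` carries 4-chlorophenyl in place of 3-chlorophenyl on the sulfonyl sulfur, and in this assay compound 2 gives 6%. The step of a number 6 percentage points higher from compound 1 to compound 2 (within the scatter) is small, so the two numbers cannot be ranked against each other. Compound 3 `CNC(=O)/C=C1/COc2c1ccc(OS(=O)(=O)c1cccc(Cl)c1)c2C` differs from compound 1 by methyl in place of hydrogen on an aromatic carbon. Among the compounds with values here, no measured step touches this change, and the only known step, a number 6 percentage points higher from compound 1 to compound 2 (within the scatter), stayed within the scatter, so no shift beyond the scatter is expected. Compound 3 is therefore estimated at 3%, ranging from -5% to 15%, an expected step of a number 3 percentage points higher from compound 1 to compound 3 (within the scatter).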

Compound 3, a percentage reported as inhibition, at one concentration (the size of the read-out at that concentration, not a potency): 2%
Estimate against measurement, compound 3: 1 percentage points above; measured number inside the range.
By their numbers in this assay, from the lowest: compounds 1, 3 and 2 (each within the scatter of the next).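

Methyl in place of hydrogen on an aromatic carbon, ortho to a fused ring and ortho to a large group, leaves this assay without a shift beyond the scatter (a number 2 percentage points higher from compound 1 to compound 3 (within the scatter)). This is the first change shown on the shared core rather than on the chlorophenyl group, and here too compound 1 and compound 3 cannot be ranked. Nothing available explains this result. From the compounds shown here alone, whether an ethyl, a methoxy or an amine on this carbon would shift the number remains open. So does the effect of the same methyl on compound 2.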